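This account rests on a few compounds, and the source may have more. Where it says the series, first, only, none or still open, it means among the compounds named here.

Measured compounds:
compound 1 `Cc1c(OCCCCOc2ccc(C(=O)O)cc2)ccc(C(=O)CC2CCCC2)c1O` with 26.7%;
compound 2 `Cc1c(OCCCCOc2ccc(C(=O)C(C)C)c(O)c2C)cccc1C(=O)O` with 27.1%;
compound 3 `Cc1c(OCCCCOc2ccc(C(=O)O)cc2)ccc(C(=O)CC2CCCC2)c1C` with 12.2%.

In an assay on HEK293 cells for positive allosteric modulation of metabotropic glutamate receptor 3 (Rattus norvegicus), read by thallium flux, with a stated time of 2.5 min (a higher number here means a larger maximal response, a lower number a smaller maximal response), compound 1 stands second highest of the three numbers; compound 2 lies within the scatter of it, while compound 3 lies beyond the scatter below it. Among the measured compounds shown here, the only step that differs in one place is a number 14.5 percentage points lower from compound 1 to compound 3 (beyond the scatter), which involves the other end of the molecule. Compound 4 `COc1ccc(C(=O)O)cc1OCCCCOc1ccc(C(=O)CC2CCCC2)c(O)c1C` differs from compound 1 by 5-carboxy-2-methoxyphenyl in place of 4-carboxyphenyl on an oxygen on a saturated carbon. For the measured compounds named here, no measured step bears on this change; compounds 1 and 2 show only that a differently substituted carboxyphenyl end gave numbers within the scatter of each other. Accordingly the account expects no step beyond the scatter, an estimated a number 1.7 percentage points lower from compound 1 to compound 4 (within the scatter). For compound 4 the estimate is 25%, within 12% to 40%.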

Compound 4, largest response reached (reported as percent of maximum), in percent of the reference or control that the assay uses: 67.6%
Compound 4: middle estimate off by 42.6 percentage points, on the low side, and the stated range ends below it.
By their numbers in this assay, from the lowest: compound 3; then compounds 1 and 2 (each within the scatter of the next); then compound 4.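

In this assay the replacement of 4-carboxyphenyl by 5-carboxy-2-methoxyphenyl on an oxygen on a saturated carbon gives a number 40.9 percentage points higher from compound 1 to compound 4 (beyond the scatter) and so shows that the maximal response depends strongly on this end of the molecule. Among the compounds shown here, this single change, with the rest of compound 1 kept, is the first step measured at this position. No measurement at hand accounts for the rise.

The compounds shown leave open whether the methoxy group or the changed carboxy placement carries the step. They also leave open whether an ethoxy group or a chlorine atom in place of methoxy would hold the response.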